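A few compounds are considered here, and "the series" means these few. Any claim that something is new, unique, unknown or untested is made for them only; others in the source may bear on it.

Measured in a functional assay on KB cells (Homo sapiens) for inhibition, read by MTT assay, with a stated time of 24 h, tested at 1 ug/mL; a lower number here means less inhibition of growth, a higher number more inhibition of growth at the concentration tested:

- compound 1 `O=C(O)CCCCC(CCSC(=O)c1ccccc1)SC(=O)c1ccccc1` gives 0.68%
- compound 2 `O=C(CCCCC(S)CCS)Nc1cccc2ccccc12` gives "not active" (no number reported)
- compound 3 `O=C(CCCCC(CCSC(=O)c1ccccc1)SC(=O)c1ccccc1)Nc1ccccc1` gives "not active" (no number reported)

Compound 3 has no single number in this assay and stands as "not active" (no number reported) on the record. One further entry, compound 2, is also without a number. Among the compounds with values here, the only numeric entry is compound 1 at 0.68% and no measured pair differs in one place, so the series offers no step to size a change.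

Compound 4 `O=C(CCCCC(CCSC(=O)c1ccccc1)SC(=O)c1ccccc1)Nc1ccccc1Cl` departs from compound 3 by a single change: chloro in place of hydrogen on an aromatic carbon with chloro in place of hydrogen on an aromatic carbon, ortho to a large group. Phenylcarbamoyl thus becomes (2-chlorophenyl)carbamoyl.

No step beyond the usual scatter is expected in this assay and no direction is favoured. This expectation rests on compound 3 at "not active" (no number reported) and on compound 1 at 0.68% as the nearest reference points. Another report without a number would be no surprise. For compound 4 the growth inhibition is estimated at 3% with an expected range from 0% to 14% as the working figure.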

Compound 4, percent growth inhibition at one concentration: 3.05%
Compound 4: middle estimate off by 0.1 percentage points, on the low side; the range from low to high includes it.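

With chloro in place of hydrogen on an aromatic carbon, ortho to a large group, compound 4 carries a number in this assay, whereas compound 3 stands as "not active" with none, so the size of this change cannot be read. Putting (2-chlorophenyl)amino in place of hydroxy on a carbonyl carbon gives a number 2.4 percentage points higher from compound 1 to compound 4 (within the scatter) and so offers the series its first readable step, one that does not separate the carboxylic acid from this anilide at the concentration tested. No measurement at hand accounts for either result.

Open, on these data alone, is whether a methoxy group or a nitrile in place of this chloro would take growth inhibition beyond the scatter. Also open, as far as these compounds go, is whether a longer chain between the amide carbonyl and the sulfur-bearing carbon would do so.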